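This account rests on a few compounds, and the source may have more. Where it says the series, first, only, none or still open, it means among the compounds named here.

Measured in a functional assay on CHO-K1 cells with Glucose-dependent insulinotropic receptor (Homo sapiens) as the target, read by a luciferase reporter, with a stated time of 5 h; a lower number here means a smaller maximal response, a higher number a larger maximal response:
compound 1 `CCOC(=O)N1CCC(Oc2ncnc3c2CCN3c2ccc(S(C)(=O)=O)cc2F)CC1`: 135%
compound 2 `CC(C)COC(=O)N1CCC(Oc2ncnc3c2CCN3c2ccc(S(C)(=O)=O)cc2F)CC1`: 94%
compound 3 `CC(C)(C)COC(=O)N1CCC(Oc2ncnc3c2CCN3c2ccc(S(C)(=O)=O)cc2F)CC1`: 80%

Compound 3 stands lowest of the three, separated from compound 2 by a number 14 percentage points lower from compound 2 to compound 3 (beyond the scatter) and from compound 1 by a number 55 percentage points lower from compound 1 to compound 3 (beyond the scatter). Compound 4 `CS(=O)(=O)c1ccc(N2CCc3c(OC4CCN(C(=O)OCCF)CC4)ncnc32)c(F)c1` differs from compound 3 by fluoromethyl in place of tert-butyl on a saturated chain carbon bound to an oxygen next to a carbonyl group. Going by the values given here, the steps that bear on it are a number 41 percentage points lower from compound 1 to compound 2 (beyond the scatter) and a number 55 percentage points lower from compound 1 to compound 3 (beyond the scatter), both large, both lowering the maximal response as the group on that carbon grew from methyl. Here the tert-butyl leaves and the smaller fluoromethyl enters, so a large step upward in this assay is expected, back toward compound 1, since the entering 2-fluoroethyl is close in size to the ethyl of compound 1. Compound 4 is estimated at 125% (range 95% to 155%), a step of a number 45 percentage points higher from compound 3 to compound 4 (beyond the scatter).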

Compound 4, largest response reached (reported as percent of maximum), in percent of the reference or control that the assay uses: 86%
Estimate against measurement, compound 4: 39 percentage points above, outside the stated range (below it).
By their numbers in this assay, from the lowest: compounds 3, 4 and 2 (each within the scatter of the next, the first and the last beyond it); then compound 1.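

Fluoro in place of hydrogen on the ethyl chain of compound 1 is by itself a large change, a number 49 percentage points lower from compound 1 to compound 4 (beyond the scatter), so in this assay a small group at this place does not by itself keep the maximal response high, and compound 4 goes against a reading by group size alone. Fluoromethyl in place of tert-butyl gives a number 6 percentage points higher from compound 3 to compound 4 (within the scatter), and in place of isopropyl it gives a number 8 percentage points lower from compound 2 to compound 4 (within the scatter). Nothing shown accounts for the effect of the fluorine.

Open, on these data alone, is whether a propyl chain at this place stays with compound 1 or falls with compound 4. Also open, as far as these compounds go, is what a 2-methoxyethyl or 2,2-difluoroethyl group would do.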